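The source may hold more compounds than are shown below. What is called first, only, known or untested is meant among the compounds shown, and "the series" means these compounds.

Measured to date in a functional assay on A-431 cells (Homo sapiens) for cytotoxicity, read by MTT assay, with a stated time of 24 h; a higher number here means a weaker inhibitor, a lower number a stronger inhibitor:

- compound 1, `COc1ccc(/C=C\C(=O)O)c(OCc2cn(-c3ccc(NC(C)=O)cc3)nn2)c1CC=C(C)C`: 23400 nM
- compound 2, `COc1ccccc1-n1cc(COc2c(/C=C\C(=O)O)ccc(OC)c2CC=C(C)C)nn1`: 32600 nM
- compound 3, `COc1ccc(/C=C\C(=O)O)c(OCc2cn(-c3ccccc3F)nn2)c1CC=C(C)C`: 12400 nM

All three numbers sit in a narrow band. Compound 3 gives the lowest number of the three; one of its gaps is a 1.9-fold lower number from compound 1 to compound 3 (0.28 log units; within the scatter), so within the scatter, while the other, a 2.6-fold lower number from compound 2 to compound 3 (0.42 log units; beyond the scatter), is modest but real. The step of a 1.4-fold higher number from compound 1 to compound 2 (0.14 log units; within the scatter) is within the scatter as well. On these numbers compound 3 cannot be called the strongest, only the lowest so far.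

Compound 4, `COc1cccc(-n2cc(COc3c(/C=C\C(=O)O)ccc(OC)c3CC=C(C)C)nn2)c1`, differs from compound 3 by 3-methoxyphenyl in place of 2-fluorophenyl on an aromatic nitrogen. Within the data shown here, the step that bears most directly on it is the one between compound 2 and compound 3, where a methoxyphenyl went to a fluorophenyl on the same aromatic nitrogen and the number fell by a 2.6-fold lower number from compound 2 to compound 3 (0.42 log units; beyond the scatter). Going back from fluoro to methoxy, now at a different position on the phenyl, is expected to undo some of that, while the spread among compounds 1, 2 and 3 suggests any movement stays small.

The expected step is a 1.8-fold higher number from compound 3 to compound 4 (0.25 log units; within the scatter), towards a higher number. For compound 4 the estimate in this assay is 22000 nM, with a range of 9000 nM to 55000 nM.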

Compound 4, half-maximal inhibitory concentration: 23200 nM
Beside the measured number, compound 4's estimate is 1.1-fold (0.02 log units) below it, and the stated range covers the measured number.
By their numbers in this assay, from the lowest: compounds 3, 4, 1 and 2 (each within the scatter of the next, the first and the last beyond it).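

In this assay, 3-methoxyphenyl in place of 2-methoxyphenyl on the aromatic nitrogen gives a step within the scatter (a 1.4-fold lower number from compound 2 to compound 4 (0.15 log units; within the scatter)), so this read-out does not separate these two methoxyphenyl groups. The other two changes at this nitrogen, from 2-fluorophenyl (a 1.9-fold higher number from compound 3 to compound 4 (0.27 log units; within the scatter)) and from 4-acetamidophenyl (a 1.0-fold lower number from compound 1 to compound 4 (0.00 log units; within the scatter)), are also within the scatter, which places compound 4 within the scatter of all three earlier compounds and leaves one gap beyond it in the series (a 2.6-fold lower number from compound 2 to compound 3 (0.42 log units; beyond the scatter)). That single modest gap rests on one pair and does not make a trend across the aryl groups at this nitrogen, and no independent measurement is available to account for any of these steps.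

Still open, from the compounds shown here alone, is whether an amine or a carboxylic acid on the phenyl, or a longer chain in place of the phenyl, would move the number beyond the scatter from these four compounds. Also open, going by these compounds, is how 3-fluorophenyl or 4-methoxyphenyl would compare, which would show whether the gap between the 2-fluorophenyl and 2-methoxyphenyl compounds holds with the substituent elsewhere on the phenyl.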